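The source may hold more compounds than are shown below. What is called first, only, known or untested is meant among the compounds shown, and "the series" means these compounds.

Measured compounds:
- compound 1 `Cc1ccc(C2C(C#N)=C(N)N(c3ccc(S(N)(=O)=O)cc3)C3=C2C(=O)CCC3)cc1` — 30%
- compound 2 `N#CC1=C(N)N(c2ccc(S(N)(=O)=O)cc2)C2=C(C(=O)CCC2)C1c1cccc([N+](=O)[O-])c1` — 42%
- compound 3 `N#CC1=C(N)N(c2ccc(S(N)(=O)=O)cc2)C2=C(C(=O)CCC2)C1c1ccc(Cl)cc1Cl` — 40%

All three share one core and differ only in the aryl group on a saturated ring carbon. In a functional assay on Ehrlich cells (Mus musculus) for antiproliferative activity, read by trypan blue exclusion, with a stated time of 2 h, tested at 10 ug/mL (on this read-out higher numbers stand for a stronger effect at the one concentration tested and lower numbers for a weaker effect), compound 3 gives 40%, the second highest of the three numbers. One gap is a number 2 percentage points lower from compound 2 to compound 3 (within the scatter), and the other is a number 10 percentage points higher from compound 1 to compound 3 (within the scatter), so compound 3 is not separable from either neighbour. Among the measured compounds shown here, the only step that clears the scatter is a number 12 percentage points higher from compound 1 to compound 2 (beyond the scatter), a modest one.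

Compound 4 `N#CC1=C(N)N(c2ccc(S(N)(=O)=O)cc2)C2=C(C(=O)CCC2)C1c1c(O)ccc2ccccc12` has not been measured in this assay. It differs from compound 3 by 2-hydroxynaphthalen-1-yl in place of 2,4-dichlorophenyl on a saturated ring carbon. For the measured compounds named here, the three measured steps bear on it only in that each is an aryl exchange at the same saturated ring carbon; none of them introduces a second aromatic ring or a hydrogen-bond donor, so no measured step speaks directly to the entering group. Of the three, two are within the scatter and one is modest. The expected step from compound 3 to compound 4 in this assay is therefore a number 2 percentage points higher from compound 3 to compound 4 (within the scatter), that is, none beyond the scatter, with a wide range to reflect the untested group. Compound 4 is estimated at 42%, between 25% and 60%.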

Compound 4, a percentage reported as activity, at one concentration (the size of the read-out at that concentration, not a potency): 0%
Estimate against measurement, compound 4: 42 percentage points above, and the stated range ends above it.
By their numbers in this assay, from the lowest: compound 4; then compounds 1, 3 and 2 (each within the scatter of the next, the first and the last beyond it).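

This position is not indifferent to the aryl group: in this assay 2-hydroxynaphthalen-1-yl gives a number 40 percentage points lower from compound 3 to compound 4 (beyond the scatter) and a number 42 percentage points lower from compound 2 to compound 4 (beyond the scatter) and a number 30 percentage points lower from compound 1 to compound 4 (beyond the scatter) on the same saturated ring carbon, so compound 4 is the weakest of the series. The three earlier aryl groups, 4-methylphenyl, 3-nitrophenyl and 2,4-dichlorophenyl, differ from each other by a modest step at most, so the range of groups accepted here has a limit that they did not reveal. The change brings in a second aromatic ring and a hydroxyl together, and no available measurement explains the loss of the read-out.

The compounds shown leave open whether the second aromatic ring or the hydroxyl goes with the loss, a question that an unsubstituted naphthyl group and a hydroxyphenyl group at this carbon would separate. Also open, going by these compounds, is whether a methoxy group in place of the hydroxyl on the naphthalene would return the read-out to the level of the other three compounds.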